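The source may hold more compounds than are shown below. What is called first, only, known or untested is meant among the compounds shown, and "the series" means these compounds.

Measured in a toxicity assay on NIH3T3 cells (Mus musculus) for cytotoxicity, read by resazurin assay; a lower number here means that less compound is needed, a higher number that more compound is needed for the effect:

Compound 1 `COC(=O)c1ccc(NCc2cncn2Cc2ccccc2C)cc1-c1ccccc1`: 10000 nM
Compound 2 `COC(=O)c1ccc(NCc2cncn2Cc2ccccc2Cl)cc1-c1ccccc1`: 10000 nM
Compound 3 `Cc1ccc(Cn2cncc2CNc2cccc(-c3ccccc3)c2)cc1`: 10000 nM

Compound 3 stands level with compounds 1 and 2, so all three compounds give the same reading in this assay. The next structure is compound 4 `COC(=O)c1ccc(NCc2cncn2Cc2ccc(C)cc2)cc1-c1ccccc1`, which has a methoxycarbonyl in place of hydrogen on an aromatic carbon of compound 3: methoxycarbonyl in place of hydrogen on an aromatic carbon.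

For the measured compounds named here, only one step between measured compounds differs in a single place, and it involves a different change, chloro in place of methyl: no change at the digits printed from compound 1 to compound 2 (within the scatter). It shows no movement, but it says nothing directly about adding a methoxycarbonyl. The more useful evidence is that compound 1 already carries this group and gives 10000 nM, the same reading as compound 3. Compound 2 also carries it and gives 10000 nM. No change beyond the scatter is therefore expected in this assay, in either direction. The expected step is no change at the digits printed from compound 3 to compound 4 (within the scatter). Compound 4 is estimated at 10000 nM, with an expected range of 6000 nM to 16000 nM.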

Compound 4, half-maximal effective concentration: 50000 nM
Estimate against measurement, compound 4: 5.0-fold (0.70 log units) below; measured number above the stated range.
By their numbers in this assay, from the lowest: compounds 1, 2 and 3 (each within the scatter of the next); then compound 4.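

For the compounds shown here, on the aromatic carbon ortho to a phenyl group, methoxycarbonyl in place of hydrogen is the first change to move the number in this assay beyond the scatter, with a 5.0-fold higher number from compound 3 to compound 4 (0.70 log units; beyond the scatter). The methoxycarbonyl does not act alone in this small set: with it in place, 4-methylphenyl instead of 2-methylphenyl gives a 5.0-fold higher number from compound 1 to compound 4 (0.70 log units; beyond the scatter), and 4-methylphenyl instead of 2-chlorophenyl gives a 5.0-fold higher number from compound 2 to compound 4 (0.70 log units; beyond the scatter), so the aromatic group on the saturated chain carbon also matters. Nothing available here explains these higher numbers.

As far as these compounds go, whether a carboxylic acid or an amide on the same aromatic carbon would shift the number as well remains open. So does the effect of 4-chlorophenyl on the chain carbon, which would show whether the rise seen with 4-methylphenyl also holds with chloro.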